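Swapping a furan for an imidazole on the shared core

The compounds below may be only part of what the source reports. "The series", "measured", "known", "first", "only" and "open" are said of these compounds alone.

Compounds measured so far:
- compound 1, `Cc1cc(-n2ccnc2)cn2c(CSCCc3ccccc3)cnc12`: 100 ug/mL
- compound 2, `Cc1cc(-n2ccc3cccnc32)cn2c(CSCCc3ccccc3)cnc12`: 20 ug/mL
- compound 3, `Cc1cc(-c2ccco2)c2ncc(CSCCc3ccccc3)n2c1`: 100 ug/mL

The read-out throughout is an ADME assay on HEL cells (Homo sapiens) for cytotoxicity, with a stated time of 3 days; a lower number here means that less compound is tolerated, a higher number that more compound is tolerated. Within the data shown here, compound 3 sits level with compound 1 at the digits reported, and together the two show the highest numbers of the three; compound 2 is the furthest away, with a 5.0-fold lower number from compound 1 to compound 2 (0.70 log units; beyond the scatter) marking the only step beyond the scatter among the measured compounds.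

Compound 4, `Cc1cc(-n2ccnc2)c2ncc(CSCCc3ccccc3)n2c1`, has not yet been tested. It differs from compound 3 in one place: 1H-imidazol-1-yl in place of furan-2-yl on an aromatic carbon. Among the measured compounds shown here, the only measured step, the one from compound 1 to compound 2, concerns a different change at a different kind of position, so it does not bear directly on this swap. What the numbers do show is that compound 1, which carries the same 1H-imidazol-1-yl group on a related core, gives 100 ug/mL, and compound 3 gives 100 ug/mL, both at the top of the measured range.

For the measured compounds named here, with no step speaking for a shift, compound 4 is expected to stay within the scatter of compound 3, so the expected step is no change at the digits printed from compound 3 to compound 4 (within the scatter). Compound 4 is therefore estimated at 100 ug/mL, with a range from 50 ug/mL to 200 ug/mL.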

Compound 4, minimum cytotoxic concentration: 20 ug/mL
Estimate against measurement, compound 4: 5.0-fold (0.70 log units) above; the whole stated range lies above it.
By their numbers in this assay, from the lowest: compounds 2 and 4 (each within the scatter of the next); then compounds 1 and 3 (each within the scatter of the next).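

In this assay, putting 1H-imidazol-1-yl in place of furan-2-yl on this aromatic carbon, ortho to a fused ring and meta to a methyl group, gives a 5.0-fold lower number from compound 3 to compound 4 (0.70 log units; beyond the scatter), so this position responds to which five-membered aromatic ring it carries. The two groups have the same number of heavy atoms, whereas the earlier step, a 5.0-fold lower number from compound 1 to compound 2 (0.70 log units; beyond the scatter), brought in a larger group at a different place on the shared core; a lower number in this assay therefore does not require a gain in heavy atoms. What the swap itself changes to produce this step cannot be said, as nothing here measures any property of these two groups or of the compounds that carry them.

The compounds shown leave open whether other groups on this carbon, such as a phenyl ring, a thiophen-2-yl ring or a simple amine, would stay level with compound 3 or fall towards compound 4 in this assay. They also leave open whether the same furan-2-yl to 1H-imidazol-1-yl swap would give a similar step at any other position on the shared core.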